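The compounds below may be only part of what the source reports. "The series", "measured", "known", "first", "only" and "open" are said of these compounds alone.

Three compounds of the shared core have numbers in a functional assay on SW-620 cells (Homo sapiens) for cytotoxicity, read by MTT assay, with a stated time of 72 h; on this read-out higher numbers stand for weaker inhibition and lower numbers for stronger inhibition. Compound 1 `COc1ccc(/C=C2\CCC/C(=C\c3ccccc3Cl)C2=O)cc1OC` gives 7100 nM. Compound 2 `COc1ccc(/C=C2\CCC/C(=C\c3cccc(Br)c3)C2=O)cc1OC` gives 4200 nM. Compound 3 `COc1ccc(/C=C2\CCC/C(=C\c3ccc(O)cc3)C2=O)cc1OC` gives 7700 nM, the highest number of the three, though its gap to each of the others is within the scatter: a 1.1-fold higher number from compound 1 to compound 3 (0.04 log units; within the scatter) and a 1.8-fold higher number from compound 2 to compound 3 (0.26 log units; within the scatter). The remaining measured step, a 1.7-fold lower number from compound 1 to compound 2 (0.23 log units; within the scatter), is likewise within the scatter, so across the three aryl groups tried the read-out is flat.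

Compound 4 `COc1ccc(/C=C2\CCC/C(=C\c3ccc(O)c(O)c3)C2=O)cc1OC` is the next member. Relative to compound 3 the change is hydroxy in place of hydrogen on an aromatic carbon. Among the measured compounds shown here, no measured step adds a hydroxy group, so nothing directly matches this change; the steps that bear on it are the three exchanges of the aryl group, a 1.1-fold higher number from compound 1 to compound 3 (0.04 log units; within the scatter), a 1.8-fold higher number from compound 2 to compound 3 (0.26 log units; within the scatter) and a 1.7-fold lower number from compound 1 to compound 2 (0.23 log units; within the scatter), none of which moved the number beyond the scatter. The change to compound 4 keeps the 4-hydroxyphenyl seen in compound 3 and adds to it, and on the flat picture so far no step beyond the scatter is expected in this assay in either direction. For compound 4 the estimate is 7000 nM, with a range from 3000 nM to 18000 nM. The expected step is a 1.1-fold lower number from compound 3 to compound 4 (0.04 log units; within the scatter).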

Compound 4, half-maximal inhibitory concentration: 10500 nM
The estimate for compound 4 lay 1.5-fold (0.18 log units) below the measured number; the measured number falls inside the stated range.
By their numbers in this assay, from the lowest: compounds 2, 1, 3 and 4 (each within the scatter of the next, the first and the last beyond it).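

In this assay, among the compounds shown here, the added hydroxy on an aromatic carbon, ortho to a hydroxy group, gives the first direct reading of a change at this place, and the step stays within the scatter (a 1.4-fold higher number from compound 3 to compound 4 (0.13 log units; within the scatter)), so 3,4-dihydroxyphenyl and 4-hydroxyphenyl cannot be told apart here. For the compounds shown here, the same compound supplies the first step beyond the scatter, a modest one (a 2.5-fold higher number from compound 2 to compound 4 (0.40 log units; beyond the scatter)), while its step from the 2-chlorophenyl member remains within the scatter (a 1.5-fold higher number from compound 1 to compound 4 (0.17 log units; within the scatter)), so the flat picture now has one exception, the pair of 3-bromophenyl and 3,4-dihydroxyphenyl, with compound 4 the weaker of those two only. Nothing on hand gives a reason for these numbers.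

The compounds shown leave open whether an amine or a carboxylic acid in place of the added hydroxy would move the number beyond the scatter from compound 3. They also leave open whether the gap between compound 2 and compound 4 reflects anything more than the two ends of a narrow spread of values.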